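The source may report more compounds than this note shows. Statements on the series, on what has been measured and on what is new or still open speak of the compounds shown alone.

Of the compounds shown here, three sharing one core have been measured so far: compound 1 `COc1cccc([C@H](O)[C@H]2CO[C@H](c3ccc(OC)c(OC)c3)[C@@H](C/C=C/c3ccc(OC)c(OC)c3)C2)c1`, compound 2 `COc1ccc([C@H]2OC[C@H]([C@@H](O)c3ccc(OC)c(OC)c3)C[C@@H]2C/C=C/c2ccc(OC)c(OC)c2)cc1` and compound 3 `COc1ccc(/C=C/C[C@@H]2C[C@H]([C@H](O)c3ccc(OC)c(OC)c3)CO[C@H]2c2ccc(OC)c(OC)c2)cc1OC`. In a functional assay on HeLa cells (Homo sapiens) for cytotoxicity, read by WST assay, with a stated time of 48 h (a higher number here means a weaker inhibitor, a lower number a stronger inhibitor), compound 1 gives 21200 nM. In this assay compound 2 gives 46700 nM, the highest of the three numbers, although its gap to compound 3 is within the usual scatter, so those two cannot be ranked against each other; only the gap to compound 1 lies beyond the scatter. In this assay compound 3 gives 28700 nM.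

The step of interest leads from compound 2 to compound 4 `COc1ccc(/C=C/C[C@H]2C[C@@H]([C@@H](O)c3ccc(OC)c(OC)c3)CO[C@@H]2c2ccccc2)cc1OC`, not yet measured. The change is hydrogen in place of methoxy on an aromatic carbon; cut one bond further out, a 4-methoxyphenyl becomes a phenyl. Among the compounds with values here, no measured pair differs in only this place, so nothing measured shows what this change does here. Within the data shown here, since the three known numbers lie close together, the expected step is a 1.2-fold lower number from compound 2 to compound 4 (0.07 log units; within the scatter), small and within the scatter, in no firm direction. Compound 4 is expected to give 40000 nM in this assay, with a range from 15000 nM to 100000 nM.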

Compound 4, half-maximal inhibitory concentration: 17000 nM
Compound 4: middle estimate off by 2.4-fold (0.37 log units), on the high side, within the range that was stated.
By their numbers in this assay, from the lowest: compounds 4, 1, 3 and 2 (each within the scatter of the next, the first and the last beyond it).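

In this assay, replacing the methoxy of the 4-methoxyphenyl with hydrogen, which leaves a phenyl, gives a 2.7-fold lower number from compound 2 to compound 4 (0.44 log units; beyond the scatter), a modest step but one beyond the scatter. Within the data shown here, this is the first single-place change in the set, and it shows that this position, para to a large group on an aromatic ring, does affect the read-out and that the methoxy there is not required for the cytotoxicity seen. No available evidence bears on why the number falls when this group leaves.

One step cannot show how other replacements at this position would behave, such as fluorine, a hydroxyl or an amine. It also leaves open whether removing a methoxy from either of the other aromatic rings would shift the number in the same direction.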